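Methoxyphenyl Amide in Place of a Cinnamoyl Group

The source may hold more compounds than are shown below. What is called first, only, known or untested is meant among the compounds shown, and "the series" means these compounds.

Compound 1, `O=C(Nc1cc(Sc2ncn[nH]2)c(O)c2ccccc12)c1cccc([N+](=O)[O-])c1`: in a functional assay on PC-3 cells (Homo sapiens) for antiproliferative activity, read by MTT assay, with a stated time of 48 h (on this read-out higher numbers stand for weaker inhibition and lower numbers for stronger inhibition), compound 1 gives 26900 nM.
Compound 2, `O=C(/C=C/c1ccccc1)Nc1cc(Sc2ncn[nH]2)c(O)c2ccccc12`: in this assay compound 2 gives > 100000 nM, which is a limit of the assay rather than a number.

Compound 2 therefore stands at the weak end of what has been measured so far; its value is only a limit, (the limit of > 100000 nM in this assay, at which 1 of the 2 values shown sits), so its true position is known only as lying beyond that point. Among the measured compounds shown here, the one measured step that touches the same position on the carbonyl carbon is an at least 3.7-fold higher number from compound 1 to compound 2 (0.57 log units; beyond the scatter), showing that the 2-phenylethenyl group costs activity relative to an aryl amide.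

Compound 3, `COc1cccc(C(=O)Nc2cc(Sc3ncn[nH]3)c(O)c3ccccc23)c1`, differs from compound 2 by 3-methoxyphenyl in place of 2-phenylethenyl on a carbonyl carbon. This returns to an aryl group directly on the carbonyl, as in compound 1, which gives 26900 nM. Compound 3 is therefore expected to land near compound 1, with an expected step of an at least 2.5-fold lower number from compound 2 to compound 3 (0.39 log units; beyond the scatter). In this assay compound 3 is estimated at 40000 nM, within a range of 12000 nM to 150000 nM.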

Compound 3, half-maximal inhibitory concentration: 42100 nM
Beside the measured number, compound 3's estimate is 1.1-fold (0.02 log units) below it; the measured number falls inside the stated range.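

In this assay, 3-methoxyphenyl in place of 2-phenylethenyl on the carbonyl carbon gives an at least 2.3-fold lower number from compound 2 to compound 3 (0.37 log units; beyond the scatter), so a second aryl group set directly on the carbonyl, after the 3-nitrophenyl of compound 1, also stands clear of compound 2. Between the two aryl amides, methoxy in place of nitro on an aromatic carbon gives a 1.6-fold higher number from compound 1 to compound 3 (0.19 log units; within the scatter), a gap that does not set them apart, so this swap on the aromatic ring shows no effect that can be read in this assay. The true size of the step from the cinnamoyl amide remains unknown because the value of compound 2 is only a limit: the limit of > 100000 nM in this assay, at which 1 of the 3 values shown sits.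

The compounds shown do not separate the loss of the double bond from the other differences between 2-phenylethenyl and an aryl group on the carbonyl carbon. They also leave open whether an amine or a carboxylic acid on that aromatic ring, or a saturated alkyl chain on the carbonyl carbon, would move the number beyond what the two aryl amides show.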